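Sulfonyl series notes: cyclopropyl to 2,4-difluorophenyl

The source may hold more compounds than are shown below. What is called first, only, known or untested is meant among the compounds shown, and "the series" means these compounds.

Compound 1 `Cc1cc(C)cc(S(=O)(=O)c2c(C(=O)NC3CNC3)[nH]c3ccc(Cl)cc23)c1` gives 37300 nM
Compound 2 `Cc1cc(C)cc(S(=O)(=O)c2c(C(=O)N[C@@H]3CCN(Cc4cccnc4)C3)[nH]c3ccc(Cl)cc23)c1` gives 36500 nM
Compound 3 `Cc1cc(C)cc(S(=O)(=O)c2c(C(=O)NS(=O)(=O)C3CC3)[nH]c3ccc(Cl)cc23)c1` gives 147000 nM

In an ADME assay on MT4 cells (Homo sapiens) for cytotoxicity, read by MTT assay, with a stated time of 5 days (a higher number here means that more compound is tolerated, a lower number that less compound is tolerated), compound 3 gives 147000 nM as the highest of the three numbers. The change 2,4-difluorophenyl in place of cyclopropyl on a sulfonyl sulfur leads to compound 4 `Cc1cc(C)cc(S(=O)(=O)c2c(C(=O)NS(=O)(=O)c3ccc(F)cc3F)[nH]c3ccc(Cl)cc23)c1` and puts 2,4-difluorophenyl in place of cyclopropyl on a sulfonyl sulfur. Within the data shown here, no measured step makes this swap, and there is no second sulfonyl compound to compare. Closest come a 3.9-fold higher number from compound 1 to compound 3 (0.60 log units; beyond the scatter) and a 4.0-fold higher number from compound 2 to compound 3 (0.61 log units; beyond the scatter) as modest steps on an amide-type nitrogen, while a 1.0-fold lower number from compound 1 to compound 2 (0.01 log units; within the scatter) stays within the scatter. Starting from the top number, a modest fall of similar size is expected, and the expected step is a 2.1-fold lower number from compound 3 to compound 4 (0.32 log units; beyond the scatter) on thin evidence. Compound 4 is estimated at 70000 nM within an expected range of 20000 nM to 180000 nM for now.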

Compound 4, half-maximal cytotoxic concentration: 121000 nM
For compound 4 the middle estimate is 1.7-fold (0.24 log units) below the measured one, and the stated range covers the measured number.
By their numbers in this assay, from the lowest: compounds 2 and 1 (each within the scatter of the next); then compounds 4 and 3 (each within the scatter of the next).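

In this assay, 2,4-difluorophenyl replaces cyclopropyl on the sulfonyl sulfur with no readable shift, a 1.2-fold lower number from compound 3 to compound 4 (0.08 log units; within the scatter), so an aromatic six-membered ring is tolerated here as well as the three-membered ring. The higher numbers of the acyl sulfonamide type are therefore not specific to cyclopropyl, with a 3.3-fold higher number from compound 2 to compound 4 (0.52 log units; beyond the scatter) and a 3.2-fold higher number from compound 1 to compound 4 (0.51 log units; beyond the scatter), both modest. Nothing available explains why the swap leaves the number in place. Open, going by these compounds, is whether a longer alkyl chain on the sulfonyl sulfur, or a phenyl ring carrying a carboxylic acid or an amine, stays in this range.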